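Trimming a Carbonyl from a Nucleoside Side Chain

The compounds below may be only part of what the source reports. "The series", "measured", "known", "first", "only" and "open" are said of these compounds alone.

Compound 2 `Cc1cn([C@@H]2O[C@H](CO[Si](C)(C)C(C)(C)C)[C@@]3(OS(=O)(=O)C=C3NCC(=O)C(N)=O)[C@H]2O[Si](C)(C)C(C)(C)C)c(=O)n(C)c1=O` carries a (carbamoylcarbonyl)methyl group on an amine nitrogen. In a functional assay on HEL cells (Homo sapiens) for cytotoxicity, read by microscopy (on this read-out higher numbers stand for lower toxicity in this test and lower numbers for higher toxicity in this test), compound 2 gives only a limit, >= 16000 nM, rather than a measured number. Compound 1 `Cc1cn([C@@H]2O[C@H](CO[Si](C)(C)C(C)(C)C)[C@@]3(OS(=O)(=O)C=C3NC(=O)NC(=O)c3ccccc3)[C@H]2O[Si](C)(C)C(C)(C)C)c(=O)n(C)c1=O` differs from compound 2 in carrying benzoylcarbamoyl on that nitrogen. In this assay compound 1 likewise gives a limit, >= 80000 nM. The step that the two limits leave unreadable from compound 1 to compound 2 is therefore not readable, since both values sit at limits, the limit of >= 16000 nM in this assay, at which 1 of the 2 values shown sits, and (the limit of >= 80000 nM in this assay, at which 1 of the 2 values shown sits). Compound 3 `Cc1cn([C@@H]2O[C@H](CO[Si](C)(C)C(C)(C)C)[C@@]3(OS(=O)(=O)C=C3NCCC(N)=O)[C@H]2O[Si](C)(C)C(C)(C)C)c(=O)n(C)c1=O` differs from compound 2 in one place: carbamoylmethyl in place of carbamoylcarbonyl on a saturated chain carbon bound to an amine nitrogen. Among the measured compounds shown here, no measured step speaks to this kind of change, so nothing beyond the usual scatter is expected in either direction in this assay. Compound 3 is therefore expected to give about 20000 nM, in a range from 8000 nM to 80000 nM, which means an expected step that the limit leaves unreadable from compound 2 to compound 3, and most likely the result will again be reported only as a limit.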

Compound 3, minimum cytotoxic concentration: >= 80000 nM
Compound 3 was reported as a limit; the forecaster's own chance of this, stated with the estimate: 80%; middle value at least 4.0-fold (0.60 log units) away from the limit.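

In this assay compound 3 gives only a limit, as do compound 1 and compound 2, so no step among these compounds can be read. The compounds shown leave open whether their side chains on the amine nitrogen differ in toxicity at all, and by how much.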